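The source may report more compounds than this note shows. Statements on the series, on what has been measured and on what is new or still open speak of the compounds shown alone.

Compound 3 `Nc1nc(NCc2ccccc2)c2ncn(/C=C3/CC3(CO)CO)c2n1` carries a benzylamino group on the shared core. In an ADME assay on CCRF-HSB-2 cells (Homo sapiens) for cytotoxicity, with a stated time of 7 days (on this read-out higher numbers stand for lower toxicity in this test and lower numbers for higher toxicity in this test), compound 3 reaches only > 20000 nM, which is a limit of the test rather than a measured number. Two relatives of compound 3 do give full numbers. Compound 1 `CCCCSc1nc(N)nc2c1ncn2/C=C1/CC1(CO)CO`, with a butylsulfanyl group in that position, gives 89000 nM in this assay. Compound 2 `CC(C)CSc1nc(N)nc2c1ncn2/C=C1/CC1(CO)CO`, with an isobutylsulfanyl group there, gives 60000 nM in this assay. The step of a 1.5-fold lower number from compound 1 to compound 2 (0.17 log units; within the scatter) shows that swapping one short branched chain for a straight one on the sulfur changes little. The steps a step that the limit leaves unreadable from compound 1 to compound 3 and a step that the limit leaves unreadable from compound 2 to compound 3 cannot be sized because of the limit of > 20000 nM in this assay, at which 1 of the 3 values shown sits.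

Compound 4 `Nc1nc(SC2CCCC2)c2ncn(/C=C3/CC3(CO)CO)c2n1` is the next point. Its change from compound 3 is cyclopentylsulfanyl in place of benzylamino on an aromatic carbon. This brings back a group attached through sulfur, as in compound 1 with 89000 nM and compound 2 with 60000 nM, so compound 4 is expected to land near those two numbers. The step that the limit leaves unreadable from compound 3 to compound 4 is therefore expected to move away from the limit of compound 3 toward a readable value. Compound 4 is estimated at 70000 nM, with a likely range from 20000 nM to 200000 nM.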

Compound 4, half-maximal cytotoxic concentration: 91000 nM
Compound 4: the middle estimate sits 1.3-fold (0.11 log units) below what was measured; the range from low to high includes it.
By their numbers in this assay, from the lowest: compounds 2, 1 and 4 (each within the scatter of the next).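

In this assay, putting cyclopentyl in place of isobutyl on the sulfur gives a 1.5-fold higher number from compound 2 to compound 4 (0.18 log units; within the scatter), and putting it in place of butyl gives a 1.0-fold higher number from compound 1 to compound 4 (0.01 log units; within the scatter). The earlier compounds shown here showed only that a straight and a branched chain on the sulfur read alike, whereas compound 4 shows that a five-membered non-aromatic ring of carbon on the sulfur also reads alike with both. The step from the benzylamino group of compound 3 to the cyclopentylsulfanyl group of compound 4 cannot be read, because the result for compound 3 is a limit and not a number: the limit of > 20000 nM in this assay, at which 1 of the 4 values shown sits.

Going by these compounds, it remains open whether swapping the sulfur for a nitrogen matters on its own, a question that a cyclopentylamino group, differing from compound 4 in that one atom, could address directly. Also open, on these data alone, is whether any group on this aromatic carbon moves the number beyond the scatter, for example a phenylsulfanyl group, a much longer chain on the sulfur, or a simple amine.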